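This account rests on a few compounds, and the source may have more. Where it says the series, first, only, none or still open, it means among the compounds named here.

Within the data shown here, compound 1 `CCOC(=O)[C@@H]1CC(=O)c2sccc2[C@H]1c1ccc(OC)cc1` is the weaker of the two measured compounds on the numbers so far: in a physicochemical assay, with a stated time of 60 min, tested at 80 ug/mL (a higher number here means a stronger effect of the compound at the concentration tested, a lower number a weaker effect), compound 1 gives 31%, the lowest of the two values, and in the same assay compound 2 `CCOC(=O)[C@@H]1CC(=O)c2sccc2[C@H]1c1ccc(OCC)cc1` gives 34.1%. Among the measured compounds shown here, the only measured step, a number 3.1 percentage points higher from compound 1 to compound 2 (within the scatter), concerns a methyl in place of hydrogen on a saturated chain carbon bound to an oxygen on the aromatic ring, and it is within the scatter.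

Compound 3 `CCOC(=O)[C@@H]1CC(=O)c2sccc2[C@H]1c1ccc(OC)c(OC)c1` has not been measured. It differs from compound 1 by methoxy in place of hydrogen on an aromatic carbon. For the measured compounds named here, no measured step alters the aromatic ring itself, so the step from compound 1 to compound 2 is the only point of comparison, and it bears on compound 3 only loosely, since it changes the chain rather than adds a group to the ring. Given that the one measured step is small and within the scatter, no step beyond the scatter is expected in this assay from compound 1 to compound 3; the expected step is a number 2 percentage points higher from compound 1 to compound 3 (within the scatter). For compound 3 the estimated value in this assay is 33%, with a range from 18% to 48%.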

Compound 3, a percentage reported as activity, at one concentration (the size of the read-out at that concentration, not a potency): 30.4%
Estimate against measurement, compound 3: 2.6 percentage points above, and the stated range covers the measured number.
By their numbers in this assay, from the lowest: compounds 3, 1 and 2 (each within the scatter of the next).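

Methoxy in place of hydrogen on an aromatic carbon, ortho to a methoxy group and meta to a large group, gives a number 0.6 percentage points lower from compound 1 to compound 3 (within the scatter) in this assay, and this is the first measured change on the six-membered aromatic ring itself rather than on the chain bound to its oxygen. This position therefore accepts an added group of 2 heavy atoms with no step beyond the scatter, and the same holds for the chain change, which gives a number 3.1 percentage points higher from compound 1 to compound 2 (within the scatter), so neither of the two kinds of change tried on compound 1 has yet moved this read-out measurably. No measured information on the compounds accounts for this result.

Going by these compounds, whether a different group at this ring position, such as an amine, a carboxylic acid or a fluorine atom, would give a step beyond the scatter remains open. Also open, on these data alone, is whether the read-out responds to a longer chain on the ring oxygen, or to a change away from the aromatic ring, such as a carboxylic acid in place of the ethyl ester.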